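A few compounds are considered here, and "the series" means these few. Any claim that something is new, unique, unknown or untested is made for them only; others in the source may bear on it.

In an ADME assay on C8166 cells (Homo sapiens) for cytotoxicity, read by MTT assay (on this read-out lower numbers stand for higher toxicity in this test and higher numbers for lower toxicity in this test), compound 1 `O=C(O)c1cn(-c2ccccc2)c2ccc(Cc3cccc(Cl)c3F)c(O)c2c1=O` gives 388000 nM, compound 2 `Cc1ccc(-n2cc(C(=O)O)c(=O)c3c(O)c(Cc4cccc(Cl)c4F)ccc32)cc1` gives 194000 nM and compound 3 `O=C(O)c1cn(Cc2ccccc2)c2ccc(Cc3ccccc3F)c(O)c2c1=O` gives 156000 nM. Compound 2 holds the middle place among these three numbers, and its value lies within the scatter of both others. Compound 4 `Cc1ccc(Cn2cc(C(=O)O)c(=O)c3c(O)c(Cc4cccc(Cl)c4F)ccc32)cc1` differs from compound 2 in one place: 4-methylbenzyl in place of 4-methylphenyl on an aromatic nitrogen, with 4-methylbenzyl in place of 4-methylphenyl on an aromatic nitrogen. For the measured compounds named here, no measured step changes that group. Going by the values given here, the only measured step, a 2.0-fold lower number from compound 1 to compound 2 (0.30 log units; within the scatter), is methyl in place of hydrogen on an aromatic carbon, and it stays within the scatter. No change beyond the scatter is therefore expected. The estimated step is a 1.1-fold lower number from compound 2 to compound 4 (0.04 log units; within the scatter). Compound 4 is expected at 175000 nM, within an estimated range of 75000 nM to 400000 nM.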

Compound 4, half-maximal cytotoxic concentration: 256000 nM
Compound 4: the middle estimate sits 1.5-fold (0.17 log units) below what was measured; low and high end bracket the measured number.
By their numbers in this assay, from the lowest: compounds 3, 2, 4 and 1 (each within the scatter of the next, the first and the last beyond it).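

In this assay, for the compounds shown here, 4-methylbenzyl in place of 4-methylphenyl on the aromatic nitrogen gives a 1.3-fold higher number from compound 2 to compound 4 (0.12 log units; within the scatter) and stays within the scatter, the first measured step to change the group at this position. 4-methylbenzyl in place of phenyl there gives a 1.5-fold lower number from compound 1 to compound 4 (0.18 log units; within the scatter) and also stays within the scatter, so these groups on this nitrogen cannot be told apart by this read-out. No evidence on the cause is at hand. The compounds shown leave open whether an amine or a longer chain on that nitrogen, in place of 4-methylbenzyl, would also stay within the scatter.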